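Piperidine for methylpiperazine on the shared core

A few compounds are considered here, and "the series" means these few. Any claim that something is new, unique, unknown or untested is made for them only; others in the source may bear on it.

Of the compounds shown here, two have been measured in an assay on cells for displacement of a labelled ligand from adenosine receptor A2b (Homo sapiens), read by scintillation counting and radioligand binding, with a stated time of 30 min, tested at 10 uM; a higher number here means more inhibition at the concentration tested (going by the name of the read-out), a lower number less inhibition. Compound 1 `Cn1cnc2c(N3CCCCC3)nc(-c3cc(Cl)ccc3Cl)nc21` gives 31%. Compound 2 `CN1CCN(c2nc(-c3cc(Cl)ccc3Cl)nc3[nH]cnc23)CC1` gives 13%, the lower of the two numbers; its distance to compound 1 is beyond the scatter, so the inhibition in this assay is lower for compound 2 than for compound 1.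

Compound 3 `Clc1ccc(Cl)c(-c2nc(N3CCCCC3)c3nc[nH]c3n2)c1` is the next compound, not yet measured in this assay. It differs from compound 2 in one place: piperidin-1-yl in place of 4-methylpiperazin-1-yl on an aromatic carbon. Going by the values given here, no step between measured compounds with this same change exists, so the size is not calibrated. Compound 1 also bears piperidin-1-yl and gives 31%, which is the only pointer available.

For compound 3 the inhibition is expected to rise modestly, as a step of a number 12 percentage points higher from compound 2 to compound 3 (beyond the scatter), taking it above the scatter around compound 2. The estimate for compound 3 is 25%, with a range from 5% to 45%.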

Compound 3, a percentage reported as inhibition, at one concentration (the size of the read-out at that concentration, not a potency): 12.1%
Compound 3: middle estimate off by 12.9 percentage points, on the high side, and the stated range covers the measured number.
By their numbers in this assay, from the lowest: compounds 3 and 2 (each within the scatter of the next); then compound 1.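

In this assay the exchange of 4-methylpiperazin-1-yl for piperidin-1-yl on this aromatic carbon gives a number 0.9 percentage points lower from compound 2 to compound 3 (within the scatter), so with hydrogen on the aromatic nitrogen the two groups cannot be told apart at this position. Hydrogen in place of methyl on the aromatic nitrogen gives a number 18.9 percentage points lower from compound 1 to compound 3 (beyond the scatter), so the higher number of compound 1 goes with that methyl and not with piperidin-1-yl alone. Nothing measured here accounts for either step.

From the compounds shown here alone, it remains open whether 4-methylpiperazin-1-yl on the methylated core would read the same as piperidin-1-yl. Also open, going by these compounds, are how an ethyl group on the aromatic nitrogen or a morpholin-4-yl group on the aromatic carbon would read.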